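From (carboxymethyl)sulfamoyl to phenylsulfonyl on the shared core

This account rests on a few compounds, and the source may have more. Where it says the series, first, only, none or still open, it means among the compounds named here.

Compound 1 `C#CCN(Cc1ccc2nc(C)nc(O)c2c1)c1ccc([N+](=O)[O-])c(C(F)(F)F)c1`: 5000 nM
Compound 2 `C#CCN(Cc1ccc2nc(C)nc(O)c2c1)c1ccc(S(=O)(=O)NCC(=O)O)c(C(F)(F)F)c1`: > 75000 nM, a limit

Compound 2 has no exact number in a functional assay on L1210 cells (Mus musculus) for inhibition (on this read-out lower numbers stand for stronger inhibition and higher numbers for weaker inhibition), only a limit: the limit of > 75000 nM in this assay, at which 1 of the 2 values shown sits. Compound 3 `C#CCN(Cc1ccc2nc(C)nc(O)c2c1)c1ccc(S(=O)(=O)c2ccccc2)c(C(F)(F)F)c1` carries phenyl in place of (carboxymethyl)amino on a sulfonyl sulfur. Among the measured compounds shown here, the one measured step that bears on this change, an at least 15-fold higher number from compound 1 to compound 2 (1.17 log units; beyond the scatter), is large and brought in the (carboxymethyl)sulfamoyl group that compound 3 lacks. A large move to a lower number is therefore expected, with the expected step being an at least 12-fold lower number from compound 2 to compound 3 (1.09 log units; beyond the scatter). For compound 3 the estimated value is 6000 nM, with an expected range of 1500 nM to 30000 nM.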

Compound 3, half-maximal inhibitory concentration: 2000 nM
Compound 3: middle estimate off by 3.0-fold (0.48 log units), on the high side, and the stated range covers the measured number.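

In this assay, a sulfonyl group on this aromatic carbon is compatible with inhibition when it carries phenyl: the swap for (carboxymethyl)amino gives an at least 37-fold lower number from compound 2 to compound 3 (1.57 log units; beyond the scatter), so the weak result of compound 2 does not follow from the sulfonyl group alone. The figure for compound 2 is a limit, not a number: the limit of > 75000 nM in this assay, at which 1 of the 3 values shown sits. Replacing nitro with phenylsulfonyl gives a 2.5-fold lower number from compound 1 to compound 3 (0.40 log units; beyond the scatter), so this position accepts a much larger group than nitro.

The compounds shown leave open how a plain amino or methyl group on the sulfonyl sulfur would read. They also do not show whether the carboxylic acid or the rest of the (carboxymethyl)amino group accounts for the loss.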